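This account rests on a few compounds, and the source may have more. Where it says the series, first, only, none or still open, it means among the compounds named here.

Three compounds built around a linker joining a double-bonded chain to a coumarin-like ether have been measured in a functional assay on THP-1 cells (Homo sapiens) for inhibition, read by sulforhodamine B assay, with a stated time of 48 h, tested at 50 uM; a higher number here means more inhibition of growth at the concentration tested, a lower number less inhibition of growth. Compound 1 `COc1cc(/C=C/C(=O)/C=C/c2cc(OC)c(OC)c(OC)c2)ccc1OCc1cn(CCOc2cc(=O)oc3ccccc23)nn1` gives 99% in this assay. Compound 2 `COc1cc(/C=C/C(=O)/C=C/c2ccccc2)ccc1OCc1cn(CCOc2cc(=O)oc3ccccc23)nn1` gives 61% in this assay, and compound 3 `COc1cc(/C=C/C(=O)/C=C/c2ccccc2)ccc1OCc1cn(CCCOc2cc(=O)oc3ccccc23)nn1` gives 48% in this assay. Compound 3 sits lowest of the three. The cores of compound 2 and compound 3 differ in a way that is not broken down here. The change from compound 2 to compound 1 is 3,4,5-trimethoxyphenyl in place of phenyl on a double-bonded chain carbon bound to a double-bonded chain carbon, and it made a step of a number 38 percentage points higher from compound 2 to compound 1 (beyond the scatter). Compound 4 `COc1cc(/C=C/C(=O)/C=C/c2cc(OC)c(OC)c(OC)c2)ccc1OCc1cn(CCCOc2cc(=O)oc3ccccc23)nn1` is not yet measured; it carries the same change against compound 3, namely (3,4,5-trimethoxyphenyl in place of phenyl on a double-bonded chain carbon bound to a double-bonded chain carbon). Resting on the step from compound 2 to compound 1, a step of about a number 36 percentage points higher from compound 3 to compound 4 (beyond the scatter) is expected from compound 3 to compound 4 in this assay, though the upper end of the scale limits how far it can rise. Compound 4 is therefore estimated at 84% in this assay, plausibly between 64% and 99%.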

Compound 4, percent growth inhibition at one concentration: 79%
Compound 4: the middle estimate sits 5 percentage points above what was measured; the measured number falls inside the stated range.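

In this assay, 3,4,5-trimethoxyphenyl in place of phenyl again gave a large rise, a number 31 percentage points higher from compound 3 to compound 4 (beyond the scatter). Set beside the earlier step, the change carried over from one core to the other at much the same size: the same change on two cores in this assay, a number 38 percentage points higher (beyond the scatter) from compound 2 to compound 1 and a number 31 percentage points higher (beyond the scatter) from compound 3 to compound 4, 7 percentage points apart, within the scatter of two such steps. Within the data shown here, this rests on only two cores and one read-out at a single tested concentration, so it does not show that the change would carry over to other cores, nor why it raises the number.

The compounds shown leave open whether an amine or a carboxylic acid in place of the 3,4,5-trimethoxyphenyl would also raise the number. They also leave open how the change would fare with a longer chain in the linker.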